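The compounds below may be only part of what the source reports. "The series", "measured", "known", "first", "only" and "open" are said of these compounds alone.

Measured in an assay on HEK293 cells for inhibition of SCN8A/SCN1B (Homo sapiens), read by patch clamp, with a stated time of 20 min; on this read-out higher numbers stand for weaker inhibition and lower numbers for stronger inhibition:
compound 1 `CCC(c1ccccc1)N(C)c1ccc(S(=O)(=O)Nc2nccs2)cc1Cl` gives 1410 nM
compound 2 `C[C@H](Nc1cc(F)c(S(=O)(=O)Nc2cscn2)cc1Cl)c1ccccc1F` gives 410 nM

Compound 2 stands at the lower of the two numbers; the number for compound 1 is higher by a margin beyond the usual scatter, so compound 2 is the stronger inhibitor of the pair. Compound 3 `C[C@H](Nc1cc(F)c(S(=O)(=O)Nc2cscn2)cc1Cl)c1cc(CN2CCC2)ccc1F` has not yet been measured. It differs from compound 2 in one place: (azetidin-1-yl)methyl in place of hydrogen on an aromatic carbon. Among the measured compounds shown here, no measured pair shows a change of this kind, so the numbers in hand say nothing about how large a step it brings. The expectation is for a step in this assay that stays within the scatter or improves a little, because compound 2 already gives 410 nM and the rest of the molecule is unchanged. Compound 3 is therefore estimated at 300 nM, with a range of 100 nM to 900 nM. The expected step is a 1.4-fold lower number from compound 2 to compound 3 (0.14 log units; within the scatter).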

Compound 3, half-maximal inhibitory concentration: 120 nM
Compound 3: the middle estimate sits 2.5-fold (0.40 log units) above what was measured, within the range that was stated.
By their numbers in this assay, from the lowest: compound 3; then compound 2; then compound 1.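

In this assay, placing (azetidin-1-yl)methyl on an aromatic carbon, para to the fluoro group and meta to a large group, brings a 3.4-fold lower number from compound 2 to compound 3 (0.53 log units; beyond the scatter), a modest gain in inhibition that is beyond the usual scatter. This shows that the position can take a group of this size, with its four-membered ring and its nitrogen, and that inhibition grows stronger rather than being lost. No measurement shown here explains why the added group has this effect.

This single pair cannot separate the contribution of the nitrogen from that of the added carbon atoms, so a plain methyl or a hydroxymethyl group at this position would help to tell them apart. It also leaves open how a larger amine such as piperidine or morpholine, or a carboxylic acid, would fare there.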